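Fluoro to chloro on the pyridine of compound 2

The compounds below may be only part of what the source reports. "The series", "measured", "known", "first", "only" and "open" are said of these compounds alone.

The series shares one core, carrying an acrylamide and a terminal pyridine. Compound 1 `C=CC(=O)Nc1cccc(Nc2ncnc(Nc3ccc(-c4ccc(C)nc4)cc3)n2)c1` has no reported result: in a functional assay on Ramos cells (Homo sapiens) for antiproliferative activity, read by CCK-8 assay, with a stated time of 24 h (on this read-out lower numbers stand for stronger inhibition and higher numbers for weaker inhibition), compound 1 gives "not determined" (no result reported). Among the compounds with values here, compound 2 `C=CC(=O)Nc1cccc(Nc2ncnc(Nc3ccc(-c4ccc(F)nc4)cc3)n2)c1` is the only member with a number: in this assay compound 2 gives 59200 nM, so it stands alone in this set, with nothing to rank it against.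

Compound 3 `C=CC(=O)Nc1cccc(Nc2ncnc(Nc3ccc(-c4ccc(Cl)nc4)cc3)n2)c1` is not yet measured. It differs from compound 2 by chloro in place of fluoro on an aromatic carbon. Within the data shown here, no measured pair in the set shows such a change, so no step size can be read from the data; exchanging one halogen for another at this site is expected to move this assay little, in either direction, and likely not beyond the scatter.

For compound 3 the estimate is 50000 nM, with a range from 18000 nM to 140000 nM, corresponding to an expected step of a 1.2-fold lower number from compound 2 to compound 3 (0.07 log units; within the scatter).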

Compound 3, half-maximal inhibitory concentration: 160000 nM
Compound 3: middle estimate off by 3.2-fold (0.51 log units), on the low side; the measured number lies above the stated range.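

Within the data shown here, the halogen at this site is not interchangeable in this assay: 6-fluoropyridin-3-yl to 6-chloropyridin-3-yl gives a 2.7-fold higher number from compound 2 to compound 3 (0.43 log units; beyond the scatter), the only step size available so far for this position. Since higher numbers stand for weaker inhibition, chloro falls on the weaker side of fluoro, so the aromatic carbon next to the ring nitrogen responds measurably even to the exchange of one heavy atom for another. No measurement at hand accounts for the size or direction of this step.

A single step from two halogens gives no trend across substituents at this position. Going by these compounds, it remains open how a bromo, a methoxy, an amine or a nitrile at this carbon would compare with fluoro in this assay.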